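Propylcarbamoyl in place of fluoro on compound 3

This account rests on a few compounds, and the source may have more. Where it says the series, first, only, none or still open, it means among the compounds named here.

Compound 3 (`CCC1C(=O)N(C)c2cnc(-n3ccc4cc(F)ccc43)nc2N1c1ccn(C)n1`) is reported in a functional assay on Huh-7 cells (Homo sapiens) for antiproliferative activity, read by CCK-8 assay, with a stated time of 72 h (a higher number here means a weaker inhibitor of growth, a lower number a stronger inhibitor of growth), as "not active" (no number reported), so it offers no value to step from. The change to compound 4 (`CCCNC(=O)c1ccc2c(ccn2-c2ncc3c(n2)N(c2ccn(C)n2)C(CC)C(=O)N3C)c1`) is propylcarbamoyl in place of fluoro on an aromatic carbon. Two amide analogues do carry numbers: compound 1 (`CCC1C(=O)N(C)c2cnc(-n3ccc4cc(C(=O)NC(C)C)ccc43)nc2N1c1ccn(C)n1`) gives 6740 nM and compound 2 (`CCC1C(=O)N(C)c2cnc(-n3ccc4cc(C(=O)NC)ccc43)nc2N1c1ccn(C)n1`) gives 13200 nM in this assay as measured. Going by the values given here, the only measured step, methyl in place of isopropyl, is a 2.0-fold higher number from compound 1 to compound 2 (0.29 log units; within the scatter) and it bears on the amide chain alone. Compound 4 is therefore expected to give a number in the range of compound 1 (6740 nM) and compound 2 (13200 nM) rather than a not-active result. For compound 4 the estimated value is 8500 nM (expected range 3500 nM to 20000 nM).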

Compound 4, concentration for 50% growth inhibition: 7280 nM
Compound 4: the middle estimate sits 1.2-fold (0.07 log units) above what was measured; the measured number falls inside the stated range.
By their numbers in this assay, from the lowest: compounds 1, 4 and 2 (each within the scatter of the next).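

Compound 4 shows that propylcarbamoyl in place of fluoro on this aromatic carbon gives a measurable value in this assay, where compound 3 is reported as not active, although that step cannot be read as a size. The amide chain remains unresolved: the chains compared give a 1.8-fold lower number from compound 2 to compound 4 (0.26 log units; within the scatter) and a 1.1-fold higher number from compound 1 to compound 4 (0.03 log units; within the scatter), so methyl, isopropyl and propyl are not told apart. Nothing at hand explains these results. Still open, going by these compounds, is whether a longer chain, a terminal amine or a carboxylic acid at this position would separate from these amides.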